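The compounds below may be only part of what the source reports. "The series", "measured", "known", "first", "only" and "open" are said of these compounds alone.

Measured in a functional assay on MX1 cells (Homo sapiens) for inhibition, read by MTT assay, with a stated time of 120 h; on this read-out higher numbers stand for weaker inhibition and lower numbers for stronger inhibition:
- Compound 1, `CNC(=O)/C(C)=C/c1ccc(NC(=O)Nc2ccc(Cl)c(C(F)(F)F)c2)cc1`: > 50000 nM, a limit
- Compound 2, `CC(NC(=O)CCc1ccc(NC(=O)Nc2ccc(Cl)c(C(F)(F)F)c2)cc1)c1ccccc1`: > 50000 nM, a limit

Neither compound has a measured number in this assay, so the two entries cannot be ranked against each other. Compound 2 stands at a limit of the assay, > 50000 nM. The same holds for the whole set so far, which is summed up as the limit of > 50000 nM in this assay, at which 2 of the 2 values shown sit.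

Compound 3, `O=C(CCc1ccc(NC(=O)Nc2ccc(Cl)c(C(F)(F)F)c2)cc1)NC1CCC1`, keeps the rest of compound 2 and changes one group on an amide-type nitrogen, with cyclobutyl in place of 1-phenylethyl on an amide-type nitrogen. Within the data shown here, no step between two measured compounds is available to size this change. The expectation therefore rests on compound 2, whose limit is > 50000 nM. In this assay, no step beyond the usual scatter is expected, and so no clear direction is expected either. The estimated change is an at least 1.2-fold lower number from compound 2 to compound 3 (0.09 log units; that floor lies within the scatter). Compound 3 is expected at 40000 nM, with an estimated range of 12000 nM to 80000 nM. A report of only a limit is more likely than not.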

Compound 3, half-maximal inhibitory concentration: 24000 nM
Compound 3: middle estimate off by 1.7-fold (0.22 log units), on the high side; measured number inside the range.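

In this assay, among these compounds, compound 3 is the first entry with a measured number rather than a limit, which shows that a change on the amide-type nitrogen alone can bring this series into the measurable range: with cyclobutyl in place of 1-phenylethyl, the result is an at least 2.0-fold lower number from compound 2 to compound 3 (0.31 log units; beyond the scatter). The wider change on an aromatic carbon, 2-(cyclobutylcarbamoyl)ethyl in place of 2-(methylcarbamoyl)prop-1-en-1-yl, gives an at least 2.0-fold lower number from compound 1 to compound 3 (0.31 log units; beyond the scatter). Both steps lie beyond the scatter, yet each is only a floor and its full size stays unknown, because compound 1 and compound 2 carry a limit and no number: the limit of > 50000 nM in this assay, at which 2 of the 3 values shown sit.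

The step from 1-phenylethyl to cyclobutyl swaps an aromatic ring for a four-membered non-aromatic ring and also lowers the heavy-atom count, so the compounds shown cannot tell which of these goes with the lower number. They also leave open how other groups on the same amide-type nitrogen, such as cyclopentyl, cyclohexyl, isopropyl or benzyl, would read in this assay.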